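The source may hold more compounds than are shown below. What is called first, only, known or untested is meant among the compounds shown, and "the series" means these compounds.

Compound 1 `NC(=O)[C@@H](CCC(F)(F)F)N(C[C@@H]1CCOC1)S(=O)(=O)c1ccc(Cl)cc1` and compound 2 `NC(=O)[C@@H](CCC(F)(F)F)N(C[C@@H]1CCO1)S(=O)(=O)c1ccc(Cl)cc1` share a core and differ only in the ring carried on the carbon chain at the sulfonamide nitrogen. In an ADME assay on microsomes from liver (Homo sapiens) (on this read-out lower numbers stand for slow clearance and higher numbers for fast clearance), compound 1 gives 110 mL/min/kg, and in this assay compound 2 gives 83.9 mL/min/kg. Among the compounds with values here, the step of a 1.3-fold lower number from compound 1 to compound 2 (0.12 log units; within the scatter) stays within the scatter, so compound 2 holds the lowest of the two numbers measured so far without standing apart from compound 1.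

Compound 3 `NC(=O)[C@@H](CCC(F)(F)F)N(C[C@@H]1CCCO1)S(=O)(=O)c1ccc(Cl)cc1` differs from compound 2 in one place: oxolan-2-yl in place of oxetan-2-yl on a saturated chain carbon bound to a sulfonamide nitrogen. Within the data shown here, the only measured step that bears on this change, a 1.3-fold lower number from compound 1 to compound 2 (0.12 log units; within the scatter), also exchanged one saturated ring with one hetero atom for another at the same place and produced no movement beyond the scatter. Compound 3 is therefore expected to show a 1.1-fold higher number from compound 2 to compound 3 (0.05 log units; within the scatter), that is, no step beyond the scatter. The estimate for compound 3 in this assay is 95 mL/min/kg, with a range from 50 mL/min/kg to 180 mL/min/kg.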

Compound 3, clearance: 323 mL/min/kg
The estimate for compound 3 lay 3.4-fold (0.53 log units) below the measured number; the whole stated range lies below it.
By their numbers in this assay, from the lowest: compounds 2 and 1 (each within the scatter of the next); then compound 3.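

This position is not indifferent to the ring it carries. In this assay, within the data shown here, oxolan-2-yl in place of oxetan-2-yl gives the first step here beyond the scatter (a 3.8-fold higher number from compound 2 to compound 3 (0.59 log units; beyond the scatter)), and the exchange of oxolan-3-yl for oxolan-2-yl also goes beyond it (a 2.9-fold higher number from compound 1 to compound 3 (0.47 log units; beyond the scatter)), even though both of those groups are oxolanyl, so the ring's name alone does not decide the outcome. Nothing available explains why compound 3 stands apart from the other two.

Going by these compounds, it remains open whether the higher clearance is confined to oxolan-2-yl or also appears with a larger ring such as oxan-2-yl. An open chain such as 2-methoxyethyl or a nitrogen ring such as pyrrolidin-2-yl at this place could also help show how specific the jump is.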